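This account rests on a few compounds, and the source may have more. Where it says the series, first, only, none or still open, it means among the compounds named here.

Of the compounds shown here, two of this set have been measured. Compound 1 `N#CC1CN1C(=O)Nc1ccc(F)cc1` gives 7300 nM in a functional assay on L1210 cells (Mus musculus) for inhibition, read by MTT assay (a lower number here means a stronger inhibitor, a higher number a weaker inhibitor), and compound 2 `CCNC(=O)N1CC1C#N` gives 14000 nM in this assay; the gap between these two numbers lies within the scatter, so neither stands apart from the other. Compound 3 `N#CC1CN1C(=O)Nc1ccc(S(N)(=O)=O)cc1` has not been measured; it differs from compound 1 by sulfamoyl in place of fluoro on an aromatic carbon. Within the data shown here, no measured pair shows this change, so the expected step of a 1.2-fold higher number from compound 1 to compound 3 (0.09 log units; within the scatter) from compound 1 to compound 3 is estimated to stay within the scatter, with no clear direction. On that basis compound 3 is expected to give about 9000 nM in this assay, with a range from 2500 nM to 35000 nM.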

Compound 3, half-maximal inhibitory concentration: > 38000 nM
Compound 3 gave a limit, no number; the forecaster's own chance of this, stated with the estimate: 10%; at least 4.2-fold (0.62 log units) between middle value and limit.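

Compound 3 gives only a limit, > 38000 nM, in this assay, not a number. Even so, the aromatic carbon para to a group of 8 heavy atoms proves sensitive to what it carries, which the earlier compounds could not show: sulfamoyl in place of fluoro gives an at least 5.2-fold higher number from compound 1 to compound 3 (0.71 log units; beyond the scatter). As far as these compounds go, the change therefore weakens inhibition beyond the scatter, though its full size stays unknown.

The compounds shown leave open how an amine, a carboxylic acid or a methoxy group would read at this position. This single pair also cannot separate the added heavy atoms of sulfamoyl from its hydrogen-bond donor and acceptors.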